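Diterpenoid ester series: aryl sulfanyl chain variation

A few compounds are considered here, and "the series" means these few. Any claim that something is new, unique, unknown or untested is made for them only; others in the source may bear on it.

Measured so far:
- compound 1, `C=C1CC[C@@H]2[C@](C)(CO)[C@H](O)CC[C@@]2(C)[C@@H]1C/C=C1/C(=O)OC[C@H]1OC(=O)CSc1ccc(F)cc1`, 14000 nM in a functional assay on PC-3 cells (Homo sapiens) for inhibition, read by MTT assay, with a stated time of 48 h; a higher number here means a weaker inhibitor, a lower number a stronger inhibitor
- compound 2, `C=C1CC[C@@H]2[C@](C)(CO)[C@H](O)CC[C@@]2(C)[C@@H]1C/C=C1/C(=O)OC[C@H]1OC(=O)CSc1cccs1`, 18000 nM in this assay

Going by the values given here, compound 2 holds the highest of the two numbers in this assay; its nearest neighbour is compound 1, and the only measured step, a 1.3-fold higher number from compound 1 to compound 2 (0.11 log units; within the scatter), falls within the scatter, so the two values cannot be ordered.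

Compound 3, `C=C1CC[C@@H]2[C@](C)(CO)[C@H](O)CC[C@@]2(C)[C@@H]1C/C=C1/C(=O)OC[C@H]1OC(=O)CCCSc1ccc(OC)cc1`, keeps the shared core and alters only the ester side chain: 2-((4-methoxyphenyl)sulfanyl)ethyl in place of (thiophen-2-yl)sulfanyl on a saturated chain carbon bound to a carbonyl carbon. Among the compounds with values here, the one step that bears on this is a 1.3-fold higher number from compound 1 to compound 2 (0.11 log units; within the scatter), which swapped one aromatic ring on the sulfur for another without a change beyond the scatter. Within the data shown here, the step to compound 3 goes further than that: it lengthens the chain and brings a methoxy group on the ring, and no measured pair covers either of those parts. Among the measured compounds shown here, with only one flat step as guidance, the expected move in this assay is none beyond the scatter, an estimated 1.1-fold lower number from compound 2 to compound 3 (0.05 log units; within the scatter), with a wide range to cover the uncovered parts. Compound 3 is therefore expected near 16000 nM in this assay, between 5000 nM and 50000 nM.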

Compound 3, half-maximal inhibitory concentration: 19000 nM
Compound 3: middle estimate off by 1.2-fold (0.07 log units), on the low side; low and high end bracket the measured number.
By their numbers in this assay, from the lowest: compounds 1, 2 and 3 (each within the scatter of the next).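

Notes on the ester side chain: in this assay, 2-((4-methoxyphenyl)sulfanyl)ethyl in place of (thiophen-2-yl)sulfanyl gives a small step (a 1.1-fold higher number from compound 2 to compound 3 (0.02 log units; within the scatter)), and the same group in place of (4-fluorophenyl)sulfanyl also stays small (a 1.4-fold higher number from compound 1 to compound 3 (0.13 log units; within the scatter)). The earlier pair changed only the aromatic ring on the sulfur, whereas this change at the saturated chain carbon bound to a carbonyl carbon also lengthens the chain, adds a methoxy group and takes the group from 6 to 11 heavy atoms, all without a step beyond the scatter from either earlier compound. No measured data on hand explain this flat result.

Chain length and the methoxy group changed together, so the compounds shown leave open whether each alone is also flat or whether the two offset each other. From the compounds shown here alone, all three side chains also keep an aromatic ring on a sulfur, so it remains open whether an amine, a carboxylic acid or a chain longer than that of compound 3 would give a step beyond the scatter.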